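Working notes: from compound 3 to compound 4 at the ceiling

A few compounds are considered here, and "the series" means these few. Any claim that something is new, unique, unknown or untested is made for them only; others in the source may bear on it.

Compound 1 `COc1cc(N)c(Cl)cc1C(=O)NC1CCNCC1` is the shared core with a free amine nitrogen in its ring. In a functional assay on HEK293 cells for activation of 5-hydroxytryptamine receptor 4 (Homo sapiens), read by cAMP accumulation (a higher number here means a larger maximal response, a lower number a smaller maximal response), compound 1 gives > 100%, which is a limit of the assay and not a number. Compound 2 `CCN1CCC(NC(=O)c2cc(Cl)c(N)cc2OC)CC1` carries ethyl in place of hydrogen on that nitrogen. In this assay compound 2 gives > 100%, again a limit. Compound 3 `COc1cc(N)c(Cl)cc1C(=O)NC1CCN(CCCCCCCCO)CC1` carries 8-hydroxyoctyl on the same nitrogen. In this assay compound 3 gives > 100%, also a limit. The three steps measured so far are thus unreadable in size: a step that the two limits leave unreadable from compound 1 to compound 2, a step that the two limits leave unreadable from compound 1 to compound 3, and a step that the two limits leave unreadable from compound 2 to compound 3. Within the data shown here, the only evidence is the limit of > 100% in this assay, at which 3 of the 3 values shown sit, so compound 3 stands at the ceiling of this assay together with the two others.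

Compound 4 `COc1cc(N)c(Cl)cc1C(=O)NC1CCN(CCCCCCCCN2CCCCC2)CC1` differs from compound 3 as follows: piperidin-1-yl in place of hydroxy on a saturated chain carbon, eight bonds along the chain from an amine nitrogen in a ring. Among the measured compounds shown here, no measured step touches this end of the chain, and the steps that do exist give no size, only the ceiling. Compound 4 is therefore expected to remain at that ceiling. The step that the limit leaves unreadable from compound 3 to compound 4 is expected to be none beyond the scatter. The estimate for compound 4 is 105%, with a range from 90% to 120%.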

Compound 4, intrinsic activity: the largest response reached, in percent of the reference agonist's: > 100%
Compound 4 gave a limit, no number; the forecaster's own chance of this, stated with the estimate: 70%; the middle value lies beyond the limit too.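

In this assay compound 4 gives > 100%, which is a limit of the assay and not a number, so no new step can be read between compound 3 and compound 4. The compounds shown leave open whether the maximal responses of compound 1, compound 2, compound 3 and compound 4 differ at all, because all four rest on one limit: the limit of > 100% in this assay, at which 4 of the 4 values shown sit.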